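A Small Amine Replaces a Phenyl Ring

The source may hold more compounds than are shown below. What is called first, only, known or untested is meant among the compounds shown, and "the series" means these compounds.

Of the compounds shown here, two sharing one core have been tested so far. Compound 1 `CCCCCCNC(=O)n1cc(Cl)c(=O)[nH]c1=O` carries a chloro group on an aromatic carbon, and in an assay on HEK293 cells for inhibition of acid ceramidase (Rattus norvegicus), read by LC-MS, with a stated time of 30 min (a lower number here means a stronger inhibitor, a higher number a weaker inhibitor), compound 1 gives 67 nM. Compound 2 `CCCCCCNC(=O)n1cc(-c2ccccc2)c(=O)[nH]c1=O` carries a phenyl ring in that position, and in this assay compound 2 gives 177 nM. For the measured compounds named here, the one step measured so far, a 2.6-fold higher number from compound 1 to compound 2 (0.42 log units; beyond the scatter), shows that swapping the small chloro group for the larger phenyl ring weakened inhibition modestly. On the numbers shown, compound 2 therefore stands as the weaker of the two, with compound 1 as its nearest neighbour.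

Compound 3 `CCCCCCNC(=O)n1cc(NC)c(=O)[nH]c1=O` is the next compound in the series. It differs from compound 2 in one place: methylamino in place of phenyl on an aromatic carbon. Going by the values given here, the step from compound 1 to compound 2 is the only measured step that bears on this change, and it says that the phenyl ring is not favourable here. Methylamino is smaller than phenyl but is not chloro, so the outcome is uncertain. Compound 3 is expected to give a number near that of compound 2, with the step of a 2.0-fold higher number from compound 2 to compound 3 (0.30 log units; within the scatter) estimated to fall within or just beyond the scatter. The estimate for compound 3 in this assay is 350 nM. For compound 3 the expected range runs from 90 nM to 1400 nM.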

Compound 3, half-maximal inhibitory concentration: 3400 nM
Compound 3: the middle estimate sits 9.7-fold (0.99 log units) below what was measured; measured number above the stated range.
By their numbers in this assay, from the lowest: compound 1; then compound 2; then compound 3.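

In this assay methylamino in place of phenyl gives a 19-fold higher number from compound 2 to compound 3 (1.28 log units; beyond the scatter) and methylamino in place of chloro gives a 51-fold higher number from compound 1 to compound 3 (1.71 log units; beyond the scatter) so this position tolerates change far less than the modest step between the first two compounds suggested. Size alone does not put the three groups in order: methylamino has 2 heavy atoms against the 6 of phenyl, yet the smaller group moves the number further from that of compound 1, not back towards it. What does change is that methylamino brings a nitrogen, with 1 hydrogen-bond donor and 1 hydrogen-bond acceptor, where phenyl has neither, but no measurement here ties the loss of inhibition to that difference or to anything else.

Still open, on these data alone, is whether the loss follows the hydrogen on that nitrogen, the nitrogen itself, or neither, and dimethylamino and methoxy in the same place would help separate these possibilities. Methyl and fluoro would also show whether other small groups stay close to chloro or fall away like methylamino.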